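The compounds below may be only part of what the source reports. "The series", "measured", "known", "first", "only" and "open" are said of these compounds alone.

Compound 1 `CCc1cccc(NC(=O)CN2CCC(c3cccc[n+]3[O-])CC2)c1` in a functional assay on HEK293 cells for agonist activity at D(4) dopamine receptor (Homo sapiens), read by FLIPR (a lower number here means a smaller maximal response, a higher number a larger maximal response), gives 62%. Compound 2 `Cc1cccc(NC(=O)CN2CCC(c3nccs3)CC2)c1` shares the core of compound 1; in this assay compound 2 gives 62%; the two stand level at the digits shown, within the scatter, and no single-point step between measured compounds is available from these two. Compound 3 `O=C(CN1CCC(c2cccc[n+]2[O-])CC1)Nc1cccc(F)c1` carries the change (fluoro in place of ethyl on an aromatic carbon). Within the data shown here, with no measured step to lean on, the expected step of a number 2 percentage points lower from compound 1 to compound 3 (within the scatter) is small, not beyond the scatter in either direction. Compound 3 in this assay is therefore estimated at 60%, within 40% to 80%.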

Compound 3, largest response reached (reported as efficacy), in percent of the reference or control that the assay uses: 70%
Estimate against measurement, compound 3: 10 percentage points below, within the range that was stated.
By their numbers in this assay, from the lowest: compounds 1, 2 and 3 (each within the scatter of the next).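

In this assay, 3-ethylphenyl to 3-fluorophenyl gives a number 8 percentage points higher from compound 1 to compound 3 (within the scatter), the first step read at this position, on an aromatic carbon meta to a large group. At this place on the shared core, fluoro with its single heavy atom therefore stands in for the two carbons of ethyl without a step beyond the scatter. No measured data bear on why the maximal response holds across this change.

Going by these compounds, whether a chloro, a methoxy or a longer chain such as propyl at this position would stay within the scatter remains open. One pair gives no trend for this position.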